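Methyl on the ring amide nitrogen: expected gain for compound 4

A few compounds are considered here, and "the series" means these few. Any claim that something is new, unique, unknown or untested is made for them only; others in the source may bear on it.

Measured compounds:
compound 1 `CN1C(=O)[C@@]2(c3ccccc31)N(C)C[C@@H](c1ccco1)[C@@]21Cc2ccccc2C1=O`: 50.1%
compound 2 `CN1C(=O)[C@@]2(c3ccccc31)N(C)C[C@@H](c1ccc(F)cc1)[C@@]21Cc2ccccc2C1=O`: 52.9%
compound 3 `CN1C[C@@H](c2ccc(Cl)cc2)[C@@]2(Cc3ccccc3C2=O)[C@@]12C(=O)Nc1ccccc12`: 27.9%

In a functional assay on the whole organism (strain Wister albino) for inhibition, with Rattus norvegicus as the target, read by paw edema, with a stated time of 1 h, at a dose of 50 mg/kg by the intraperitoneal route (on this read-out lower numbers stand for less inhibition and higher numbers for more inhibition at the one dose given (going by the name of the read-out)), compound 3 gives 27.9%, the lowest of the three numbers; compound 1 lies above it beyond the scatter, and compound 2 lies further above it, also beyond the scatter. Compound 4 `CN1C(=O)[C@@]2(c3ccccc31)N(C)C[C@@H](c1ccc(Cl)cc1)[C@@]21Cc2ccccc2C1=O` is compound 3 with one change: methyl in place of hydrogen on an amide-type nitrogen in a ring. Going by the values given here, no measured step covers this change. Among the compounds with values here, the only measured step, a number 2.8 percentage points higher from compound 1 to compound 2 (within the scatter), swaps the group on a saturated ring carbon and says nothing about the amide-type nitrogen. What the values show is that compound 1 and compound 2, which both carry a methyl on that nitrogen, stand well above compound 3, which carries hydrogen there; yet these pairs differ in more than one place, so this is only a hint. On that hint a rise of about a number 19.1 percentage points higher from compound 3 to compound 4 (beyond the scatter) is expected. Compound 4 is estimated at 47%, between 30% and 62%.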

Compound 4, a percentage reported as inhibition, in the whole organism at one dose (the size of the read-out at that dose, not a potency): 47.2%
For compound 4 the middle estimate is 0.2 percentage points below the measured one; measured number inside the range.
By their numbers in this assay, from the lowest: compound 3; then compounds 4, 1 and 2 (each within the scatter of the next).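

In this assay the change on the amide-type nitrogen in a ring now stands alone: methyl in place of hydrogen gives a number 19.3 percentage points higher from compound 3 to compound 4 (beyond the scatter) and so backs with a one-place pair what was only a hint from compounds differing in several places. With that methyl present, chloro in place of fluoro on an aromatic carbon gives a number 5.7 percentage points lower from compound 2 to compound 4 (within the scatter) and 4-chlorophenyl in place of furan-2-yl gives a number 2.9 percentage points lower from compound 1 to compound 4 (within the scatter), so among these compounds only the change on the nitrogen stands clear of the scatter. No measurement shown accounts for the rise that comes with the methyl.

From the compounds shown here alone, only hydrogen and methyl appear on this nitrogen, so it stays open how a longer chain such as ethyl, or a chain ending in an amine or a carboxylic acid, would fare. It also stays open whether methyl gives a similar rise alongside the 4-fluorophenyl or furan-2-yl group, as the compounds shown hold no partner with hydrogen for either.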